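This account rests on a few compounds, and the source may have more. Where it says the series, first, only, none or still open, it means among the compounds named here.

Compound 1 `CC(Oc1cccnc1Nc1cnn(C)c1)c1cccc(C(=O)NCc2ccc(Cl)c(C(F)(F)F)c2)c1` gives 50700 nM in a functional assay on NCI-H3122 cells (Homo sapiens) for antiproliferative activity, read by MTT assay, with a stated time of 48 h; on this read-out lower numbers stand for stronger inhibition and higher numbers for weaker inhibition.
Compound 2 `CC(Oc1cccnc1Nc1cnn(C)c1)c1cccc(C(=O)NCc2ccccc2S(=O)(=O)C(C)C)c1` gives only a limit of the assay, > 100000 nM, in this assay.
Compound 3 `Cc1ccc(CNC(=O)c2cccc(C(C)Oc3cccnc3Nc3ncccn3)c2)cc1` gives only a limit of the assay, > 100000 nM, in this assay.

Compound 3 therefore stands at the ceiling of this assay, where (the limit of > 100000 nM in this assay, at which 2 of the 3 values shown sit); no number is known for it, only that it inhibits growth too weakly to be quantified. Within the data shown here, the single measured step, an at least 1.9-fold higher number from compound 1 to compound 2 (0.29 log units; that floor lies within the scatter), changes a group on the saturated chain carbon bound to an amide-type nitrogen, a different part of the molecule, and runs into the same ceiling, so it offers no direct guidance here. The change in question is 1-(2-hydroxy-2-methylpropyl)-1H-pyrazol-4-yl in place of pyrimidin-2-yl on a nitrogen on an aromatic ring, which gives compound 4 `Cc1ccc(CNC(=O)c2cccc(C(C)Oc3cccnc3Nc3cnn(CC(C)(C)O)c3)c2)cc1`. Among the measured compounds shown here, no measured pair isolates this change. Compound 1 carries a different group on that nitrogen and does give a number in this assay. Compound 3, with pyrimidin-2-yl on that nitrogen, gives only a limit. On that basis compound 4 is expected to move back below the ceiling by a modest margin, an at least 2.5-fold lower number from compound 3 to compound 4 (0.39 log units; beyond the scatter). The estimate for compound 4 is 40000 nM, with a range from 10000 nM to 150000 nM, and a real chance that only a limit is reported again.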

Compound 4, half-maximal inhibitory concentration: 9100 nM
Compound 4: the middle estimate sits 4.4-fold (0.64 log units) above what was measured; the measured number lies below the stated range.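

Exchanging the pyrimidin-2-yl on this nitrogen for 1-(2-hydroxy-2-methylpropyl)-1H-pyrazol-4-yl in this assay gives an at least 10-fold lower number from compound 3 to compound 4 (1.04 log units; beyond the scatter), the only step shown that lies clearly beyond the scatter, and it demonstrates that the group on this nitrogen can carry a compound from the limit of the assay to a real number while the rest of the molecule stays the same. Compound 3 gives only a limit, > 100000 nM, so the step is a floor and its true size may be larger. That ceiling remains a feature of this small set, and the change at this nitrogen is the one step shown that gets clear of it: the limit of > 100000 nM in this assay, at which 2 of the 4 values shown sit.

The change alters two things at once, a six-membered aromatic ring becoming a five-membered one and a chain ending in a hydroxyl group being added, so the compounds shown cannot say which of the two accounts for the gain. Also open, from the compounds shown here alone, is how the result responds to the end of that chain, for instance if an amine or a carboxylic acid took the place of the hydroxyl group on the same pyrazole.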